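The compounds below may be only part of what the source reports. "The series", "measured", "known", "first", "only" and "open" are said of these compounds alone.

Measured so far in an ADME assay on the whole organism with Oryza sativa as the target, tested at 10 uM; a lower number here means a stronger effect, a higher number a weaker effect of the compound at the concentration tested:
compound 1 `CCCCCc1ccc(NC(=O)N[C@H](C)c2ccccc2)cc1` gives 97%
compound 2 `CCCCCCCc1ccc(NC(=O)N[C@H](C)c2ccccc2)cc1` gives 100%
compound 3 `CC(=O)c1ccc(NC(=O)N[C@H](C)c2ccccc2)cc1` gives 84%

Compound 3 stands lowest of the three in this assay. The step of a number 13 percentage points lower from compound 1 to compound 3 (beyond the scatter) and the step of a number 16 percentage points lower from compound 2 to compound 3 (beyond the scatter) both lie beyond the scatter, so its separation from compound 1 and from compound 2 is real, while compound 1 and compound 2 themselves differ only by a number 3 percentage points higher from compound 1 to compound 2 (within the scatter).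

Compound 4 `C[C@@H](NC(=O)Nc1ccc(Br)cc1)c1ccccc1` has not yet been measured. It differs from compound 3 as follows:
bromo in place of acetyl on an aromatic carbon

The two measured steps that bear on this change are a number 13 percentage points lower from compound 1 to compound 3 (beyond the scatter) and a number 16 percentage points lower from compound 2 to compound 3 (beyond the scatter), in each of which an acetyl entered on the aromatic carbon and the number in this assay fell modestly. Going by the values given here, no measured step involves a bromo, so the size of the step in compound 4 is less certain than its direction. With the acetyl leaving again, a modest rise is expected, a number 9 percentage points higher from compound 3 to compound 4 (within the scatter), though a step within the scatter cannot be ruled out. Compound 4 is therefore estimated at 93% in this assay, with a range from 82% to 100%.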

Compound 4, a percentage reported as activity, at one concentration (the size of the read-out at that concentration, not a potency): 87%
Compound 4: the middle estimate sits 6 percentage points above what was measured; the range from low to high includes it.
By their numbers in this assay, from the lowest: compounds 3, 4, 1 and 2 (each within the scatter of the next, the first and the last beyond it).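

On this aromatic carbon, para to a large group, bromo and acetyl cannot be told apart in this assay: the exchange gives a number 3 percentage points higher from compound 3 to compound 4 (within the scatter) and so removes the acetyl's hydrogen-bond acceptor and double bond without a change beyond the scatter. Bromo also separates the two alkyl chains where acetyl did not, since a number 13 percentage points lower from compound 2 to compound 4 (beyond the scatter) lies beyond the scatter, whereas a number 10 percentage points lower from compound 1 to compound 4 (within the scatter) stays within it. Nothing available explains why these groups read as they do in this assay.

An amine or a carboxylic acid on this carbon would show whether other groups fall in the same range as acetyl and bromo. A short chain such as ethyl would show how small an alkyl group must be for its number to come close to theirs.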